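A few compounds are considered here, and "the series" means these few. Any claim that something is new, unique, unknown or untested is made for them only; others in the source may bear on it.

Series notes. Within the data shown here, in a functional assay on CHO cells for positive allosteric modulation of metabotropic glutamate receptor 2 (Homo sapiens), read by scintillation counting and GTPgammaS binding, with a stated time of 30 min (a lower number here means that less compound is needed, a higher number that more compound is needed for the effect), compound 3 `CCCCn1ccc(-c2ccc(Oc3ccc(C)nc3C)cc2)c(C#N)c1=O` gives 138 nM, the lowest of the three numbers so far. In this assay compound 2 `CCCCn1ccc(-c2ccc(Oc3cccnc3C)cc2)c(C#N)c1=O` gives 347 nM and compound 1 `Cc1cc(Oc2ccc(-c3ccn(CC4CC4)c(=O)c3C#N)cc2)ccn1` gives 832 nM. Among the measured compounds shown here, the only measured step, a 2.5-fold lower number from compound 2 to compound 3 (0.40 log units; beyond the scatter), concerns a methyl on an aromatic carbon and says nothing about the chain on the aromatic nitrogen. Compound 4 `Cc1ccc(Oc2ccc(-c3ccn(CC4CC4)c(=O)c3C#N)cc2)c(C)n1` differs from compound 3 by cyclopropyl in place of propyl on a saturated chain carbon bound to an aromatic nitrogen. For the measured compounds named here, compound 1 carries the same cyclopropylmethyl chain, but it also differs from compound 2 elsewhere in the molecule, so its value cannot be read as a chain effect; no measured step bears on this change. The step expected, a 1.3-fold higher number from compound 3 to compound 4 (0.12 log units; within the scatter), is therefore none beyond the scatter. Compound 4 is estimated at 180 nM, within a range from 70 nM to 450 nM.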

Compound 4, half-maximal effective concentration: 263 nM
Compound 4: middle estimate off by 1.5-fold (0.16 log units), on the low side; the measured number falls inside the stated range.
By their numbers in this assay, from the lowest: compounds 3, 4 and 2 (each within the scatter of the next, the first and the last beyond it); then compound 1.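

In this assay, cyclopropyl in place of propyl on a saturated chain carbon bound to an aromatic nitrogen gives a 1.9-fold higher number from compound 3 to compound 4 (0.28 log units; within the scatter), so the cyclopropylmethyl chain and the butyl chain are not separated beyond the scatter. With the cyclopropylmethyl chain held constant, 2,6-dimethylpyridin-3-yl in place of 2-methylpyridin-4-yl on an oxygen on an aromatic ring gives a 3.2-fold lower number from compound 1 to compound 4 (0.50 log units; beyond the scatter). Nothing at hand bears on the cause of either step. As far as these compounds go, how a longer chain such as hexyl, or a chain ending in an amine, would read at this place remains open. The pyridinyl step also leaves the extra methyl and the changed point of attachment unseparated.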